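The compounds below may be only part of what the source reports. "The series", "measured", "known", "first", "only" and "open" are said of these compounds alone.

Of the compounds shown here, two have been measured here. Compound 1 `Nc1nc(-c2ccc(Cl)cc2)c(CC(=O)O)s1` gives 50% in an in vitro functional assay on HEK285-7 cells for antagonist activity at prostaglandin D2 receptor 2 (Homo sapiens), read by BRET and beta-arrestin recruitment; on this read-out higher numbers stand for larger maximal responses and lower numbers for smaller maximal responses. Compound 2 `CS(=O)(=O)Nc1cccc(-c2nc(C(c3ccc(F)cc3)c3ccc(F)cc3)sc2CC(=O)O)c1` gives 80% in this assay, which is the higher of the two numbers; its gap to compound 1 lies beyond the usual scatter of repeated measurements, so compound 2 stands as the larger maximal response of the pair. No single-point change between measured compounds is available to guide the next step.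

Compound 3 `Cc1cc(-c2nc(C(c3ccc(F)cc3)c3ccc(F)cc3)sc2CC(=O)O)cnc1N` has not yet been measured. It differs from compound 2 in one place: 6-amino-5-methylpyridin-3-yl in place of 3-(methanesulfonamido)phenyl on an aromatic carbon. The group that leaves has one six-membered aromatic ring of carbon only; the group that enters has one six-membered aromatic ring with one hetero atom, and both carry one hydrogen-bond donor and two hydrogen-bond acceptors. The remainder of compound 2 is kept.

Going by the values given here, with no measured step of this kind to lean on, the expected change a number 5 percentage points lower from compound 2 to compound 3 (within the scatter) is a small one, not clearly beyond the scatter, leaning slightly downward. Compound 3 is therefore estimated at 75% in this assay, within a range from 55% to 95%.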

Compound 3, largest response reached (reported as efficacy), in percent of the reference or control that the assay uses: 80%
Compound 3: the middle estimate sits 5 percentage points below what was measured; low and high end bracket the measured number.
By their numbers in this assay, from the lowest: compound 1; then compounds 2 and 3 (each within the scatter of the next).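

Measured in this assay, replacing 3-(methanesulfonamido)phenyl with 6-amino-5-methylpyridin-3-yl on the aromatic carbon next to the ring nitrogen gives no change at the digits printed from compound 2 to compound 3 (within the scatter). Going by these compounds alone, this is the first direct view of this position, and it shows that the methanesulfonamido group is not required to keep the maximal response at this level: a group with fewer heavy atoms and a different ring, one with a hetero atom, does just as well on this read-out. Nothing available explains why the two groups read alike, and the matching numbers do not show that the two groups act in the same way.

The swap changes the ring, the amino group and the methyl group all at once, so the compounds shown leave open what each of these parts contributes. A plain pyridin-3-yl group or an unsubstituted phenyl at this place would begin to separate those contributions, and would show whether the maximal response depends on any substituent on this ring at all.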